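The compounds below may be only part of what the source reports. "The series", "measured", "known", "first", "only" and "open" are said of these compounds alone.

Compound 1 `O=C(/C=C/c1ccc2c(c1)B(O)OC2)c1ccc(F)cc1`: > 10 ug/mL
Compound 2 `O=C(/C=C/c1ccc2c(c1)B(O)OC2)c1ccc(I)cc1`: > 10 ug/mL
Compound 3 `O=C(/C=C/c1ccc2c(c1)B(O)OC2)c1ccc(Cl)cc1`: > 10 ug/mL

All three entries come from an ADME assay on L929 cells (Mus musculus) for cytotoxicity, read by resazurin assay, with a stated time of 72 h (on this read-out higher numbers stand for weaker inhibition and lower numbers for stronger inhibition), and each is a limit rather than a number. Compound 3 gives > 10 ug/mL, which is a limit. Across the series the picture is the limit of > 10 ug/mL in this assay, at which 3 of the 3 values shown sit.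

Compound 4 `O=C(/C=C/c1ccc2c(c1)B(O)OC2)c1ccc(-c2ccccc2)cc1` carries phenyl in place of chloro on an aromatic carbon. The nearest measured changes, swaps among fluoro, chloro and iodo, are a step that the two limits leave unreadable from compound 1 to compound 3, a step that the two limits leave unreadable from compound 2 to compound 3 and a step that the two limits leave unreadable from compound 1 to compound 2. They leave no size to carry over, so no particular step is expected in this assay, in either direction. The estimated step is a step that the limit leaves unreadable from compound 3 to compound 4. Compound 4 is expected at 14 ug/mL, within an estimated range of 5 ug/mL to 40 ug/mL.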

Compound 4, half-maximal inhibitory concentration: > 10 ug/mL
Compound 4: no number, only a limit; the forecaster's own chance of this, stated with the estimate: 70%; the middle value lies beyond the limit too.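

Compound 4 gives only a limit, like compound 1, compound 2 and compound 3, so no step can be read among them: the limit of > 10 ug/mL in this assay, at which 4 of the 4 values shown sit.

The compounds shown leave open whether fluoro, chloro, iodo and phenyl differ at all in this assay.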